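The source may hold more compounds than are shown below. What is called first, only, known or untested is meant among the compounds shown, and "the series" means these compounds.

In a functional assay on HCT-116 cells (Homo sapiens) for antiproliferative activity, read by MTT assay, with a stated time of 72 h (on this read-out lower numbers stand for stronger inhibition and higher numbers for weaker inhibition), compound 1 (`Nc1nc(N)c2cc(CSC(=S)N3CCN(c4ccccc4)CC3)ccc2n1`) gives 4120 nM and compound 2 (`Nc1nc(N)c2cc(CSC(=S)N3CCN(c4ccc(F)cc4F)CC3)ccc2n1`) gives 5150 nM in the same read-out, so the two stand level within the scatter. Compound 3 (`Nc1nc(N)c2cc(CSC(=S)N3CCN(c4ccccn4)CC3)ccc2n1`) takes pyridin-2-yl in place of 2,4-difluorophenyl on an amine nitrogen in a ring. Going by the values given here, the one measured step at this place is a 1.3-fold higher number from compound 1 to compound 2 (0.10 log units; within the scatter) and it stays within the scatter. Among the compounds with values here, no measured compound yet carries a hetero atom in this aromatic ring, so that step is only a weak guide. No step beyond the scatter is therefore expected in this assay for this change, and no direction is favoured. Compound 3 is estimated at 4000 nM with an expected range from 1500 nM to 10000 nM in this read-out. The expected step is a 1.3-fold lower number from compound 2 to compound 3 (0.11 log units; within the scatter) on this estimate.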

Compound 3, half-maximal inhibitory concentration: 5960 nM
Estimate against measurement, compound 3: 1.5-fold (0.17 log units) below, within the range that was stated.
By their numbers in this assay, from the lowest: compounds 1, 2 and 3 (each within the scatter of the next).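

In this assay, the step of a 1.2-fold higher number from compound 2 to compound 3 (0.06 log units; within the scatter) and the step of a 1.4-fold higher number from compound 1 to compound 3 (0.16 log units; within the scatter) show that a six-membered aromatic ring with a hetero atom, here pyridin-2-yl, can stand on this amine nitrogen in a ring without a step beyond the scatter. Going by these compounds alone, this extends the earlier comparison of phenyl and 2,4-difluorophenyl, which covered only aromatic rings of carbon: all three aromatic groups at this place now stand level, and no step among compounds 1, 2 and 3 separates them. No evidence is available that bears on why the numbers stand level.

Still open, from the compounds shown here alone, is whether a group of another kind at this place, such as benzyl or an aromatic ring carrying a carboxylic acid, would give a step beyond the scatter. The compounds shown also leave open how far the number depends on the rest of the shared core, which is the same in all three.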